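The source may hold more compounds than are shown below. What is called first, only, known or untested is meant among the compounds shown, and "the series" means these compounds.

Going by the values given here, compound 2 `N#Cc1ccc(NCCNc2ccnc3cc(Cl)ccc23)cc1` gives 39.6 ug/mL in a toxicity assay on Huh-7 cells (Homo sapiens) for cytotoxicity, read by MTT assay, with a stated time of 72 h (a lower number here means that less compound is tolerated, a higher number that more compound is tolerated), and is the only compound of the pair with a number rather than a limit. Compound 1 `Clc1ccc(NCCNc2ccnc3cc(Cl)ccc23)cc1` gives > 100 ug/mL in this assay, which is a limit and not a number. Across an at least 2.5-fold lower number from compound 1 to compound 2 (0.40 log units; beyond the scatter) the number came down; because compound 1 contributes only (the limit of > 100 ug/mL in this assay, at which 1 of the 2 values shown sits), the size of that step is known as a floor only. Compound 3 `Cc1ccc(NCCNc2ccnc3cc(Cl)ccc23)cc1` carries methyl in place of cyano on an aromatic carbon. Among the compounds with values here, no measured step bears on a methyl directly; the one measured step, an at least 2.5-fold lower number from compound 1 to compound 2 (0.40 log units; beyond the scatter), shows that the cyano which compound 3 loses went with a lower number in this assay. A modest upward step back toward the region of compound 1 is therefore expected, a 1.8-fold higher number from compound 2 to compound 3 (0.25 log units; within the scatter), with a real chance that this assay again reports only a limit. Compound 3 is expected at 70 ug/mL, between 35 ug/mL and 140 ug/mL.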

Compound 3, half-maximal cytotoxic concentration: > 100 ug/mL
Compound 3 was reported as a limit; the forecaster's own chance of this, stated with the estimate: 35%; at least 1.4-fold (0.15 log units) between middle value and limit.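

In this assay, methyl in place of cyano gives an at least 2.5-fold higher number from compound 2 to compound 3 (0.40 log units; beyond the scatter), so the lower number at this position, para to a large group, now stands against two other groups and not against chloro alone. Of the three compounds, only compound 2, the cyano compound, carries a number, which ties the lower number in this short series to cyano. The step from compound 1 to compound 3 cannot be read, because both values are limits: the limit of > 100 ug/mL in this assay, at which 2 of the 3 values shown sit.

On these data alone, whether the lower number belongs to cyano alone or returns with another group at this position, such as an amine or a carboxylic acid, stays open. As far as these compounds go, the full size of the step also stays open, as the limit for compound 3 gives a floor only.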